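This account rests on a few compounds, and the source may have more. Where it says the series, first, only, none or still open, it means among the compounds named here.

Compound 3 `Nc1nc(OCc2ccccc2Cl)c2nn[nH]c2n1` gives 180 nM in an assay on isolated protein for inhibition of Myeloperoxidase (Homo sapiens), read by fluorescence, with stated times of 10 min, 30 s and 5 min (on this read-out higher numbers stand for weaker inhibition and lower numbers for stronger inhibition), the higher of the two numbers obtained so far, above compound 2 `Nc1nc(OCc2ccccc2F)c2nn[nH]c2n1`, which gives 78 nM in this assay. Compound 1 `c1ccc(COc2ncnc3[nH]nnc23)cc1` reaches only a limit, > 13000 nM, in this assay. Among the compounds with values here, the single measured step that bears on the change at hand is a 2.3-fold higher number from compound 2 to compound 3 (0.36 log units; beyond the scatter). Compound 4 `Cc1ccccc1COc1nc(N)nc2[nH]nnc12` differs from compound 3 by methyl in place of chloro on an aromatic carbon. Within the data shown here, with only that modest step as a guide, and one that exchanged one halogen for another rather than for a methyl, the step from compound 3 to compound 4 is expected to be small, close to the scatter, in no firm direction. Compound 4 is therefore estimated at 180 nM, between 70 nM and 450 nM, an expected step of no change at the digits printed from compound 3 to compound 4 (within the scatter).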

Compound 4, half-maximal inhibitory concentration: 470 nM
The estimate for compound 4 lay 2.6-fold (0.42 log units) below the measured number, outside the stated range (above it).
By their numbers in this assay, from the lowest: compound 2; then compound 3; then compound 4. At a limit, above all of these: compound 1.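

In this assay, methyl on this aromatic carbon, ortho to a large group, is not interchangeable with either halogen: the data show a 2.6-fold higher number from compound 3 to compound 4 (0.42 log units; beyond the scatter) and a 6.0-fold higher number from compound 2 to compound 4 (0.78 log units; beyond the scatter). The three compounds with a measured number now rank fluoro, chloro, methyl from the lowest number, so this position distinguishes all three groups beyond the scatter. No data shown here account for that order. Going by these compounds, whether hydrogen, methoxy or trifluoromethyl at this position would fit within that order remains open.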